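A few compounds are considered here, and "the series" means these few. Any claim that something is new, unique, unknown or untested is made for them only; others in the source may bear on it.

Of the compounds shown here, three have numbers so far in a functional assay on HepG2 cells (Homo sapiens) for inhibition, read by MTT assay, with a stated time of 72 h; on this read-out lower numbers stand for stronger inhibition and higher numbers for weaker inhibition. Compound 1 (`COc1ccc(-c2nnc(SCCCN3CCN(c4nc5ccccc5o4)CC3)o2)cc1`) reads (66100 nM), compound 2 (`Clc1ccc(-c2nnc(SCCCN3CCN(c4nc5ccccc5o4)CC3)o2)cc1`) reads (121000 nM), and compound 3 (`Clc1ccc(-c2nnc(SCCCN3CCN(c4nc5ccccc5s4)CC3)o2)cc1`) reads (87700 nM), which places compound 3 within the usual scatter of both others. Compound 4 (`O=C(NCc1nnc(SCCCN2CCN(c3nc4ccccc4s3)CC2)o1)c1ccccc1`) carries benzamidomethyl in place of 4-chlorophenyl on an aromatic carbon. Two measured steps offer some guidance. Chloro in place of methoxy on an aromatic carbon, a change within the same aryl group that now leaves, gave (a 1.8-fold higher number from compound 1 to compound 2 (0.26 log units; within the scatter)). 1,3-Benzothiazol-2-yl in place of 1,3-benzoxazol-2-yl, a change elsewhere in the molecule, gave (a 1.4-fold lower number from compound 2 to compound 3 (0.14 log units; within the scatter)). Among the compounds with values here, both steps stayed within the scatter, yet neither replaces the whole group, so the new change has no direct precedent here. No clear movement in either direction is therefore expected in this assay, only wide uncertainty. The estimated step is (a 1.1-fold lower number from compound 3 to compound 4 (0.04 log units; within the scatter)). For compound 4 the expected value is 80000 nM, with an estimated range from 30000 nM to 200000 nM.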

Compound 4, half-maximal inhibitory concentration: 325000 nM
The estimate for compound 4 lay 4.1-fold (0.61 log units) below the measured number; measured number above the stated range.
By their numbers in this assay, from the lowest: compounds 1, 3 and 2 (each within the scatter of the next); then compound 4.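

Within the data shown here, on the five-membered aromatic ring, benzamidomethyl in place of 4-chlorophenyl gives the only step in this assay that lies beyond the usual scatter (a 3.7-fold higher number from compound 3 to compound 4 (0.57 log units; beyond the scatter)), whereas the two earlier single changes stayed within it. So replacing the whole group at this position can shift the read-out towards weaker inhibition, which swapping a substituent on the aryl group or exchanging the ring on the amine nitrogen did not do. The entering group keeps a six-membered aromatic ring of carbon only but adds an amide, and no measurement here explains the higher number.

A plain benzyl group, without the amide, would help show whether the amide or the added chain length goes with this shift. Going by these compounds, it also remains open whether benzamidomethyl gives a similar step with 1,3-benzoxazol-2-yl on the amine nitrogen.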